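The source may report more compounds than this note shows. Statements on the series, on what has been measured and on what is new or still open speak of the compounds shown alone.

In a functional assay on SK-BR-3 cells (Homo sapiens) for cytotoxicity, read by MTT assay, with a stated time of 72 h (on this read-out higher numbers stand for weaker inhibition and lower numbers for stronger inhibition), compound 1 (`Nc1cccc(Nc2c(C(=O)NCc3ccc(F)cc3)nc(Br)c3cccnc23)c1`) gives > 10000 nM, which is a limit of the assay and not a number. Among the measured compounds shown here, compound 3 (`CN(C)CCCNc1c(C(=O)NCc2ccc(F)cc2)nc(Br)c2cccnc12`) gives 1000 nM, the only actual number so far. Compound 2 (`N[C@H]1CC[C@H](Nc2c(C(=O)NCc3ccc(Oc4ccccc4)cc3)nc(Br)c3cccnc23)CC1`) stands at "not determined" (no result reported), so it offers no starting value.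

Compound 4 (`COc1ccc(CNC(=O)c2nc(Br)c3cccnc3c2N[C@H]2CC[C@H](N)CC2)cc1`) differs from compound 2 at one place: methyl in place of phenyl on an oxygen on an aromatic ring, that is, phenoxy to methoxy, with methyl in place of phenyl on an oxygen on an aromatic ring.

For the measured compounds named here, the one measured step is an at least 10-fold lower number from compound 1 to compound 3 (1.00 log units; beyond the scatter). It concerns 3-(dimethylamino)propyl in place of 3-aminophenyl on a nitrogen on an aromatic ring, not the substituent on the oxygen. Going by the values given here, no measured step covers phenoxy to methoxy, and without a number for compound 2 no size or direction of step can be expected in this assay from this comparison. Compound 4 shares its nitrogen substituent with compound 2, and neither compound in the measured step carries that substituent.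

The estimate therefore rests loosely on compound 3 at 1000 nM and is kept wide. The expected value for compound 4 is 1000 nM, with an expected range from 200 nM to 6000 nM as the estimate.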

Compound 4, half-maximal inhibitory concentration: 5000 nM
Estimate against measurement, compound 4: 5.0-fold (0.70 log units) below; measured number inside the range.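

Among the compounds shown here, for compound 2 the entry is "not determined" (no result reported) and so no step to compound 4 can be read for phenoxy to methoxy. Nothing at hand bears on the value of compound 4. The compounds shown leave open what the change from phenoxy to methoxy does to the read-out in this assay on the shared core.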